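Replacing a Pyridyl Arm with a Flexible Chain

A few compounds are considered here, and "the series" means these few. Any claim that something is new, unique, unknown or untested is made for them only; others in the source may bear on it.

Compound 2, `COc1ccc(-c2cccc(C(=O)N(C)C)n2)cc1S(=O)(=O)Nc1cccc(NCCNC(=O)c2cccc(C)c2)c1`: 226 nM
Compound 1, `COc1ccc(-c2cccc(C(=O)N(C)C)c2)cc1S(=O)(=O)Nc1cccc(N2CCN(C(=O)c3cccc(C)c3)CC2)c1`: > 10000 nM

Of the compounds shown here, two have been tested in a functional assay on CHO-RD-HGA16 cells for agonist activity at Orexin/Hypocretin receptor type 1 (Homo sapiens), read by fluorescence and calcium flux, with a stated time of 30 min; a lower number here means that less compound is needed, a higher number that more compound is needed for the effect. Compound 2 gives 226 nM there. For compound 1 the assay reports only a limit, > 10000 nM; this is the limit of > 10000 nM in this assay, at which 1 of the 2 values shown sits. Among the measured compounds shown here, compound 2 therefore stands as the only compound with an actual number, while compound 1 sits at a limit. For the measured compounds named here, no step between measured compounds is available, since compound 1 and compound 2 differ in more than one place.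

Compound 3 `COc1ccc(CCC(=O)N(C)C)cc1S(=O)(=O)Nc1cccc(NCCNC(=O)c2cccc(C)c2)c1` has not yet been measured. It differs from compound 2 by one change: 2-(dimethylcarbamoyl)ethyl in place of 6-(dimethylcarbamoyl)pyridin-2-yl on an aromatic carbon. In words, 2-(dimethylcarbamoyl)ethyl in place of 6-(dimethylcarbamoyl)pyridin-2-yl on an aromatic carbon, so a ring carrying the dimethylcarbamoyl group is exchanged for a chain carrying that same group. Going by the values given here, no measured step tells how heavily such a change weighs here. The expectation is that compound 3 needs more compound than compound 2 in this assay, by a step beyond the usual scatter an 8.8-fold higher number from compound 2 to compound 3 (0.95 log units; beyond the scatter). Compound 3 is estimated at 2000 nM, within a range from 300 nM to 10000 nM, with a real chance that only a limit is reported.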

Compound 3, half-maximal effective concentration: > 10000 nM
Compound 3 gave a limit, no number; the forecaster's own chance of this, stated with the estimate: 35%; at least 5.0-fold (0.69 log units) between middle value and limit.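

In this assay, among the compounds shown here, this is the first single change that can be read at the position para to a methoxy group, and it carries real weight: 2-(dimethylcarbamoyl)ethyl in place of 6-(dimethylcarbamoyl)pyridin-2-yl gives an at least 44-fold higher number from compound 2 to compound 3 (1.64 log units; beyond the scatter). The dimethylcarbamoyl group is present on both sides of the change, so keeping that group on a chain does not keep the response seen with the ring-bearing arm. Compound 3 gives only a limit, so the step is a minimum and its true size stays unknown: the limit of > 10000 nM in this assay, at which 2 of the 3 values shown sit.

Still open, going by these compounds, is which part of the lost arm matters, since the change removes the aromatic ring and its ring nitrogen together and also alters the distance over which the dimethylcarbamoyl group is carried. A phenyl ring bearing the same dimethylcarbamoyl group on the rest of compound 2 would address the ring nitrogen alone, while a longer chain such as 3-(dimethylcarbamoyl)propyl would show whether chain length has any bearing on the result.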